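Lengthening the butyl chain of compound 3 by one carbon

A few compounds are considered here, and "the series" means these few. Any claim that something is new, unique, unknown or untested is made for them only; others in the source may bear on it.

Measured compounds:
compound 1, `COc1cccc(-c2nc3c(-c4ccc(Cl)cc4)n[nH]c3c(=O)n2NC(=O)c2ccccc2)c1`: 87.3%
compound 2, `O=C(Nn1c(-c2ccccc2)nc2c(-c3ccc(Cl)cc3)n[nH]c2c1=O)c1ccccc1`: 92%
compound 3, `CCCCc1nc2c(-c3ccc(Cl)cc3)n[nH]c2c(=O)n1NC(=O)c1ccccc1`: 89.5%

These three numbers come from a functional assay on HT-29 cells (Homo sapiens) for cytotoxicity, read by sulforhodamine B assay, with a stated time of 2 days, tested at 100 uM; on this read-out higher numbers stand for more inhibition at the one concentration tested (going by the name of the read-out) and lower numbers for less inhibition. Compound 3 stands second highest of the three, with its nearest number from compound 1 and its furthest from compound 2. The step of a number 2.2 percentage points higher from compound 1 to compound 3 (within the scatter) and the step of a number 2.5 percentage points lower from compound 2 to compound 3 (within the scatter) both lie within the scatter, so the three compounds cannot be told apart on this read-out. Compound 4 `CCCCCc1nc2c(-c3ccc(Cl)cc3)n[nH]c2c(=O)n1NC(=O)c1ccccc1` differs from compound 3 by methyl in place of hydrogen on a saturated chain carbon, four bonds along the chain from an aromatic carbon. For the measured compounds named here, both measured steps that end at compound 3 stay within the scatter, and no measured step lengthens the chain itself. In this assay a step of a number 0.5 percentage points lower from compound 3 to compound 4 (within the scatter) is therefore expected, none beyond the scatter. Compound 4 is estimated at 89%, between 79% and 97%.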

Compound 4, a percentage reported as inhibition, at one concentration (the size of the read-out at that concentration, not a potency): 90.1%
Estimate against measurement, compound 4: 1.1 percentage points below, and the stated range covers the measured number.
By their numbers in this assay, from the lowest: compounds 1, 3, 4 and 2 (each within the scatter of the next).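

In this assay, lengthening the chain by one carbon gives a number 0.6 percentage points higher from compound 3 to compound 4 (within the scatter) and so leaves butyl and pentyl indistinguishable at this position. Pentyl also matches the ring-bearing compounds, with a number 1.9 percentage points lower from compound 2 to compound 4 (within the scatter) and a number 2.8 percentage points higher from compound 1 to compound 4 (within the scatter) so a saturated chain of this length and an aromatic ring read alike here. Nothing measured bears on why these numbers sit so close.

As far as these compounds go, whether a much longer chain, or a chain ending in an amine or a carboxylic acid, would read the same stays open. From the compounds shown here alone, whether these compounds would separate at lower concentrations also stays open.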